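Removing the (1H-imidazol-4-yl)carbonyl Group from Compound 2

The source may report more compounds than this note shows. Statements on the series, on what has been measured and on what is new or still open speak of the compounds shown alone.

In a functional assay on MSTO-211H cells (Homo sapiens) for inhibition, read by trypan blue exclusion, with a stated time of 72 h (on this read-out higher numbers stand for weaker inhibition of growth and lower numbers for stronger inhibition of growth), compound 1 `Cc1ncsc1C(=O)Oc1ccc(-c2[nH]c3ccccc3c2C)cc1` gives > 20000 nM as a limit of the assay. Compound 2 `Cc1c(-c2ccc(OC(=O)c3c[nH]cn3)cc2)[nH]c2ccccc12` gives > 20000 nM as a limit too, so it stands without a number. The evidence so far is the limit of > 20000 nM in this assay, at which 2 of the 2 values shown sit, and nothing more. Compound 3 `Cc1c(-c2ccc(O)cc2)[nH]c2ccccc12` differs from compound 2 by hydrogen in place of (1H-imidazol-4-yl)carbonyl on an oxygen on an aromatic ring and remains unmeasured. Going by the values given here, the only measured step that the two limits leave unreadable from compound 1 to compound 2 offers no size to carry over, so no step beyond the scatter is expected in this assay and another limit is likely. The expected step is a number no higher from compound 2 to compound 3 (the limit leaves the size open) on this estimate. For compound 3 the estimated value is 20000 nM with an expected range from 8000 nM to 40000 nM at its upper end.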

Compound 3, concentration for 50% growth inhibition: > 20000 nM
Compound 3 ended at the assay's limit; the forecaster's own chance of this, stated with the estimate: 70%; the middle value sits exactly at the limit.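

Compound 3, like compound 1 and compound 2, stands at a limit in this assay, so no step among these three can be read. The compounds shown leave open what would give a measurable growth inhibition here.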